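Fluoro for Bromo on a Distal Ring

A few compounds are considered here, and "the series" means these few. Any claim that something is new, unique, unknown or untested is made for them only; others in the source may bear on it.

Three compounds from one series were tested in a functional assay on MCF7 cells (Homo sapiens) for cytotoxicity, read by MTT assay, with a stated time of 72 h; a lower number here means a stronger inhibitor, a higher number a weaker inhibitor. Compound 1 `O=C(CSC(=S)N[C@H]1CCOC1=O)Nc1ccc(Br)cc1` gives 66500 nM, and compound 2 `O=C(CSC(=S)N[C@H]1CCOC1=O)Nc1ccc(F)cc1` gives 5830 nM. The change between them, (fluoro in place of bromo on an aromatic carbon), gave an 11-fold lower number from compound 1 to compound 2 (1.06 log units; beyond the scatter). Compound 3 `O=C(CSC(=S)N[C@H]1CCOC1=O)Nc1ccc(C(=O)/C=C/c2ccc(Br)cc2)cc1` carries a larger core; in this assay compound 3 gives 18700 nM. How the core of compound 3 differs from that of compound 1 is not broken down here. Compound 4 `O=C(CSC(=S)N[C@H]1CCOC1=O)Nc1ccc(C(=O)/C=C/c2ccc(F)cc2)cc1` has not yet been measured; it differs from compound 3 by fluoro in place of bromo on an aromatic carbon, the same change as from compound 1 to compound 2, at the same kind of place. On the strength of that earlier step an 11-fold lower number from compound 1 to compound 2 (1.06 log units; beyond the scatter), a lowering is expected for compound 4 in this assay, though a smaller one, since the change now sits on a different ring of the molecule. The step expected for compound 4 is estimated as a 3.7-fold lower number from compound 3 to compound 4 (0.57 log units; beyond the scatter). Compound 4 is therefore estimated at 5000 nM, between 1200 nM and 20000 nM.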

Compound 4, half-maximal inhibitory concentration: 83700 nM
The estimate for compound 4 lay 17-fold (1.22 log units) below the measured number; the measured number lies above the stated range.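

On the larger core of compound 3, fluoro in place of bromo raised the number in this assay (a 4.5-fold higher number from compound 3 to compound 4 (0.65 log units; beyond the scatter)) instead of lowering it. Within the data shown here, with only one pair on each core, this does not show why the two steps part, or how the change would behave on any other core. The step seen on the core of compound 1 did not carry over to the core of compound 3: the same change on two cores in this assay, an 11-fold lower number (1.06 log units; beyond the scatter) from compound 1 to compound 2 and a 4.5-fold higher number (0.65 log units; beyond the scatter) from compound 3 to compound 4, 51-fold (1.71 log units) apart, beyond the scatter of two such steps

The compounds shown leave open whether chloro, methoxy or an amine on the same aromatic carbon would follow either step. They also leave open which part of the larger core goes with the reversal.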